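Replacing Methoxy with Amino in Compound 2

A few compounds are considered here, and "the series" means these few. Any claim that something is new, unique, unknown or untested is made for them only; others in the source may bear on it.

Within the data shown here, in a functional assay on P388 cells (Mus musculus) for antiproliferative activity, read by colorimetric assay and MTT assay (a lower number here means a stronger inhibitor, a higher number a weaker inhibitor), compound 2 (`COc1ccc(S(=O)(=O)Nc2cccc3cc(O)[nH]c23)cc1`) gives 0.11 ug/mL, the lower of the two numbers measured so far, while compound 1 (`COc1ccc(S(=O)(=O)Nc2cccc3cc[nH]c23)cc1`) gives 1.1 ug/mL. Compound 3 (`Nc1ccc(S(=O)(=O)Nc2cccc3cc(O)[nH]c23)cc1`) keeps the core of compound 2 but has amino in place of methoxy on an aromatic carbon, para to a large group: amino in place of methoxy on an aromatic carbon. Among the measured compounds shown here, only one measured step exists, a 10-fold lower number from compound 1 to compound 2 (1.00 log units; beyond the scatter), and it is hydroxy in place of hydrogen on an aromatic carbon. That step lies at a different place, so it shows only how far a single change can move this assay in this small set. For the measured compounds named here, no measured compound varies the methoxy group, so the direction remains uncertain. A small move to a higher number is expected, with the estimated change being a 2.3-fold higher number from compound 2 to compound 3 (0.36 log units; beyond the scatter). Compound 3 is estimated at 0.25 ug/mL, with an expected range of 0.05 ug/mL to 1.2 ug/mL.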

Compound 3, half-maximal inhibitory concentration: 1.2 ug/mL
Compound 3: the middle estimate sits 4.8-fold (0.68 log units) below what was measured; the measured number falls inside the stated range.
By their numbers in this assay, from the lowest: compound 2; then compounds 1 and 3 (each within the scatter of the next).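

In this assay, amino in place of methoxy on an aromatic carbon, para to a large group, gives an 11-fold higher number from compound 2 to compound 3 (1.04 log units; beyond the scatter). Among these compounds, this is the first measured change at this position, and it shows that the position is sensitive: the step is beyond the scatter and runs opposite in direction to the earlier hydroxy step at a different place, a 10-fold lower number from compound 1 to compound 2 (1.00 log units; beyond the scatter). The swap adds a hydrogen-bond donor and removes a carbon, but no measurement here accounts for the higher number.

From the compounds shown here alone, with only methoxy and amino at this position, it remains open whether the shift comes from losing methoxy or from gaining amino, which a simple hydrogen, a chlorine or an ethoxy group there could help separate. Going by these compounds, whether amino would move the number the same way without the hydroxy group of compound 2 also remains open.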